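The compounds below may be only part of what the source reports. "The series", "measured", "known", "first", "only" and "open" are said of these compounds alone.

Three enaminones sharing one core have been tested in a functional assay on U-87MG ATCC cells (Homo sapiens) for antiproliferative activity, read by MTT assay, with a stated time of 48 h; a higher number here means a weaker inhibitor, a lower number a stronger inhibitor. Compound 1 `O=C(/C=C\Nc1ccc(C(F)(F)F)cc1)c1cn(-c2ccccc2)nc1-c1ccccc1` gives only a limit, > 50000 nM, not a number. Compound 2 `COc1cc(N/C=C\C(=O)c2cn(-c3ccccc3)nc2-c2ccccc2)cc(OC)c1OC` gives 2350 nM in this assay, the lowest of the two numbers shown. Compound 3 `COc1ccc(N/C=C\C(=O)c2cn(-c3ccccc3)nc2-c2ccc(F)cc2)cc1` gives 2500 nM in this assay, and the two numbers sit within the usual scatter of each other. Compound 4 `COc1cc(N/C=C\C(=O)c2cn(-c3ccccc3)nc2-c2ccc(F)cc2)cc(OC)c1OC` has not yet been measured. It differs from compound 2 by fluoro in place of hydrogen on an aromatic carbon. Among the compounds with values here, no single-change step between measured compounds is available to set the size of such a change, so no movement beyond the scatter is expected. Compound 4 is estimated at 2300 nM, between 1000 nM and 5500 nM, a step of a 1.0-fold lower number from compound 2 to compound 4 (0.01 log units; within the scatter) that is expected to stay within the scatter.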

Compound 4, half-maximal inhibitory concentration: 12600 nM
The estimate for compound 4 lay 5.5-fold (0.74 log units) below the measured number, outside the stated range (above it).
By their numbers in this assay, from the lowest: compounds 2 and 3 (each within the scatter of the next); then compound 4. At a limit, above all of these: compound 1.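

In this assay, the change from phenyl to 4-fluorophenyl, para to a large group, gives a 5.4-fold higher number from compound 2 to compound 4 (0.73 log units; beyond the scatter). A higher number here means a weaker inhibitor, so this position responds to one fluoro in place of hydrogen, and that response lies beyond the scatter. Nothing shown accounts for this step. The step rests on a single pair of compounds, so it cannot yet be called a general rule for this position. Going by these compounds, whether chloro, methyl or an amine on this same carbon would move the number in the same way remains open.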